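The compounds below may be only part of what the source reports. "The series", "measured", "known", "first", "only" and "open" are said of these compounds alone.

The compounds share one core and were all tested in a functional assay on SW480 cells (Homo sapiens) for cytotoxicity, read by MTT assay, with a stated time of 24 h; on this read-out lower numbers stand for stronger inhibition and higher numbers for weaker inhibition. Compound 1 `C=CC1=C(C(=O)NCc2ccccc2F)C(c2ccc(F)cc2)OC1` gives in this assay only a limit, > 100000 nM. Compound 2 `C=CC1=C(C(=O)NCc2ccc(OC)c(OC)c2)C(c2ccc(F)cc2)OC1` likewise gives in this assay a limit, > 100000 nM. Compound 3 `C=CC1=C(C(=O)NCc2ccccc2F)C(c2ccc(OC)cc2)OC1` gives in this assay a limit as well, > 100000 nM. Within the data shown here, the one single-point step among the measured compounds, methoxy in place of fluoro on an aromatic carbon, reads a step that the two limits leave unreadable from compound 1 to compound 3; both of its ends sit at the limit of > 100000 nM in this assay, at which 3 of the 3 values shown sit, so its size cannot be read. Compound 1 therefore stands nowhere on a scale: it is known only as a limit, and so are the other two values.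

Compound 4 `C=CC1=C(C(=O)NCc2ccccc2)C(c2ccc(F)cc2)OC1` differs from compound 1 by hydrogen in place of fluoro on an aromatic carbon. Among the measured compounds shown here, no measured step involves this change, and the only step available, methoxy for fluoro, is itself unreadable. For the measured compounds named here, nothing among the measured compounds suggests that the change would bring the value below the limit, since every compound in the set sits at the limit of > 100000 nM in this assay, at which 3 of the 3 values shown sit. The expected step is a step that the limit leaves unreadable from compound 1 to compound 4, that is, no readable step. Compound 4 is expected to remain at the limit, estimated at 150000 nM with a range from 50000 nM to 500000 nM.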

Compound 4, half-maximal inhibitory concentration: > 100000 nM
Compound 4 gave a limit, no number (the forecaster's own chance of this, stated with the estimate: 85%); the middle value lies beyond the limit too.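

Among these compounds, the step between compound 1 and compound 4 cannot be read, so compound 4 adds no new step, because both of its ends are limits: the limit of > 100000 nM in this assay, at which 4 of the 4 values shown sit. The compounds shown leave open whether fluoro, hydrogen or methoxy on the aromatic ring differ at all, and whether any compound on the shared core gives a measurable value.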